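Swapping the Furanyl-Ethenyl Arm for a Second Thiophene

The source may report more compounds than this note shows. Statements on the series, on what has been measured and on what is new or still open speak of the compounds shown alone.

Compound 1, `c1coc(-c2ccnc(-c3cccs3)c2)c1`: 400000 nM
Compound 2, `C(=C/c1ccco1)\c1cc(-c2ccco2)cc(-c2cccs2)n1`: < 10000 nM, a limit of the assay

In an assay on isolated protein (Triticum aestivum) for inhibition of DNA topoisomerase 1 (Homo sapiens) (a lower number here means a stronger inhibitor, a higher number a weaker inhibitor), compound 1 gives 400000 nM. Compound 2 reaches only a limit, < 10000 nM (the limit of < 10000 nM in this assay, at which 1 of the 2 values shown sits), so its true number is not known. Going by the values given here, the one measured step, an at least 40-fold lower number from compound 1 to compound 2 (1.60 log units; beyond the scatter), shows that filling this position matters. Compound 3, `c1coc(-c2cc(-c3cccs3)nc(-c3cccs3)c2)c1`, changes the same position: thiophen-2-yl in place of 2-(furan-2-yl)ethenyl on an aromatic carbon. Among the compounds with values here, no measured step covers this exact swap; the step from compound 1 to compound 2 only sets an upper bound for where compound 2 stands. For compound 3 a weakening step, an at least 1.5-fold higher number from compound 2 to compound 3 (0.17 log units; that floor lies within the scatter), is expected. Compound 3 is estimated at 15000 nM, within 3000 nM to 80000 nM.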

Compound 3, half-maximal inhibitory concentration: 50000 nM
The estimate for compound 3 lay 3.3-fold (0.52 log units) below the measured number, within the range that was stated.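

In this assay thiophen-2-yl on this aromatic carbon gives an 8.0-fold lower number from compound 1 to compound 3 (0.90 log units; beyond the scatter) on its own, so the position gains from a single aromatic ring without the ethenyl arm. The choice of group still matters: the swap from 2-(furan-2-yl)ethenyl gives an at least 5.0-fold higher number from compound 2 to compound 3 (0.69 log units; beyond the scatter) and hands back part of the gain. That step starts from a limit for compound 2: the limit of < 10000 nM in this assay, at which 1 of the 3 values shown sits.

The compounds shown leave open whether the advantage of compound 2 comes from the double bond or from its furan ring. Going by these compounds, how an amine or a carboxylic acid would fare at this position also remains open.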